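The source may report more compounds than this note shows. Statements on the series, on what has been measured and on what is new or still open speak of the compounds shown alone.

Measured in a functional assay on TK-10 cells (Homo sapiens) for inhibition; on this read-out lower numbers stand for stronger inhibition of growth and higher numbers for weaker inhibition of growth:
- compound 1 `C=C1C(=O)O[C@H]2[C@H]1CC/C(COC(=O)N1CCC(F)(F)CC1)=C\CC[C@@]1(C)O[C@@H]21`: 2600 nM
- compound 2 `C=C1C(=O)O[C@H]2[C@H]1CC/C(COC(=O)NCCN1CCCC1)=C\CC[C@@]1(C)O[C@@H]21`: 3110 nM

For the measured compounds named here, compound 2, at 3110 nM, lies within the scatter of compound 1, the only other compound measured. Compound 3 `C=C1C(=O)O[C@H]2[C@H]1CC/C(COC(=O)Nc1n[nH]c(SC)n1)=C\CC[C@@]1(C)O[C@@H]21` has 5-(methylsulfanyl)-1H-1,2,4-triazol-3-yl in place of 2-(pyrrolidin-1-yl)ethyl on an amide-type nitrogen. Going by the values given here, only one measured step bears on this, a 1.2-fold higher number from compound 1 to compound 2 (0.08 log units; within the scatter), and it involves a different pair of groups. Among the compounds with values here, no measured compound carries the entering ring, so the basis is thin. No change beyond the scatter in this assay is therefore expected, and the expected result is a 1.2-fold lower number from compound 2 to compound 3 (0.09 log units; within the scatter). For compound 3 the estimated value is 2500 nM, with an expected range of 1000 nM to 6000 nM.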

Compound 3, concentration for 50% growth inhibition: 2510 nM
Compound 3: the middle estimate sits 1.0-fold (0.00 log units) below what was measured; the range from low to high includes it.
By their numbers in this assay, from the lowest: compounds 3, 1 and 2 (each within the scatter of the next).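

In this assay, an aromatic ring can stand on the amide-type nitrogen: 5-(methylsulfanyl)-1H-1,2,4-triazol-3-yl in place of 2-(pyrrolidin-1-yl)ethyl gives a 1.2-fold lower number from compound 2 to compound 3 (0.09 log units; within the scatter), although the entering group has one five-membered aromatic ring with 3 hetero atoms and a hydrogen-bond donor. Measured against the 4,4-difluoropiperidin-1-yl carbamate, the (5-(methylsulfanyl)-1H-1,2,4-triazol-3-yl)amino group gives a 1.0-fold lower number from compound 1 to compound 3 (0.02 log units; within the scatter), so all three groups remain within the scatter of one another. No available evidence accounts for this result.

On these data alone, whether a carboxylic acid, a phenyl ring or a longer alkyl chain on this nitrogen would move the number beyond the scatter remains open.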